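Compound 4 against compound 1: chloro in place of fluoro

A few compounds are considered here, and "the series" means these few. Any claim that something is new, unique, unknown or untested is made for them only; others in the source may bear on it.

Measured so far in a functional assay on DU-145 cells (Homo sapiens) for cytotoxicity, read by MTT assay; on this read-out lower numbers stand for stronger inhibition and higher numbers for weaker inhibition:
compound 1 `CC(O)(CS(=O)(=O)c1ccc(F)cc1)c1nc(-c2ccc(Cl)cc2)no1` gives > 100000 nM
compound 2 `CC(O)(CSc1ccccc1)c1nc(-c2ccc([N+](=O)[O-])c(C(F)(F)F)c2)no1` gives 3000 nM
compound 3 `CC(O)(CSc1ccc(Cl)cc1)c1nc(-c2ccc(F)c(Cl)c2)no1` gives 500 nM

Compound 1 sits at the limit of > 100000 nM in this assay, at which 1 of the 3 values shown sits; this is a limit of this assay and not a number, so compound 1 stands at the weak end of what is shown, with no measured potency of its own. Among the compounds with values here, compound 2 and compound 3 both give numbers in this assay, but each differs from compound 1 in more than one place, so no single step toward compound 1 can be read from them.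

Compound 4 `CC(O)(CS(=O)(=O)c1ccc(Cl)cc1)c1nc(-c2ccc(Cl)cc2)no1` is not yet measured. It differs from compound 1 by chloro in place of fluoro on an aromatic carbon, leaving everything else of the shared core untouched. Within the data shown here, with compound 1 at a limit, there is no measured step that would set the size of such a change, and the series gives no second pair with the same difference to lean on.

The expectation is that the step of a number no higher from compound 1 to compound 4 (the limit leaves the size open) stays within the scatter, with compound 4 most likely also reported only as a limit. Compound 4 is estimated at 100000 nM in this assay, in the range 30000 nM to 300000 nM, because compound 1 stands at > 100000 nM.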

Compound 4, half-maximal inhibitory concentration: > 100000 nM
Compound 4: only a limit was reported; the forecaster's own chance of this, stated with the estimate: 75%; the middle value sits exactly at the limit.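

In this assay compound 4 gives > 100000 nM, a limit of the assay and not a number. Within the data shown here, compound 1 also stands at a limit, and no step for chloro in place of fluoro can be read between compound 1 and compound 4. The compounds shown leave open whether this change alters potency at all.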